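The compounds below may be only part of what the source reports. "The series", "measured", "known", "first", "only" and "open" are said of these compounds alone.

Compound 1 `S=C(SCc1cn(Cc2ccccc2Cl)nn1)N1CCNCC1`: > 128000 nM
Compound 2 `COc1cc(Cn2cc(CSC(=S)N3CCN(C(=O)OCc4ccccc4)CC3)nn2)cc(OC)c1OC`: > 128000 nM
Compound 3 `COc1cc(Cn2cc(CSC(=S)N3CCNCC3)nn2)cc(OC)c1OC`: > 128000 nM

All three values in a functional assay on ECa-109 cells (Homo sapiens) for inhibition, read by MTT assay, with a stated time of 72 h (a higher number here means a weaker inhibitor, a lower number a stronger inhibitor), are limits of the assay rather than numbers. Compound 3 therefore sits at the limit, as the limit of > 128000 nM in this assay, at which 3 of the 3 values shown sit, records, and has no readable position among the measured compounds. Compound 4 `COc1cc(Cn2cc(CSC(=S)N3CCN(C(=O)OC(C)(C)C)CC3)nn2)cc(OC)c1OC` differs from compound 3 by tert-butoxycarbonyl in place of hydrogen on an amine nitrogen in a ring. Going by the values given here, the only measured step at this nitrogen, a step that the two limits leave unreadable from compound 2 to compound 3, runs between two limits and gives no size. Compound 2 carries a benzyloxycarbonyl on the same nitrogen and also sits at the limit. The step of a number no higher from compound 3 to compound 4 (the limit leaves the size open) is accordingly expected to be none beyond the scatter. Compound 4 is expected to give 128000 nM (range 50000 nM to 400000 nM), most probably reported again only as a limit.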

Compound 4, half-maximal inhibitory concentration: 44400 nM
Beside the measured number, compound 4's estimate is 2.9-fold (0.46 log units) above it, and the stated range ends above it.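

In this assay the amine nitrogen in the ring gives its first readable step, an at least 2.8-fold lower number from compound 3 to compound 4 (0.45 log units; beyond the scatter). The group on the oxygen also matters, with an at least 2.8-fold lower number from compound 2 to compound 4 (0.45 log units; beyond the scatter), so a carbonyl on this nitrogen is not enough by itself. Both steps start from a limit and give only a least size: the limit of > 128000 nM in this assay, at which 3 of the 4 values shown sit.

Still open, going by these compounds, is whether an acetyl or a longer alkyl chain on this nitrogen also lowers the number. Also open, on these data alone, is whether tert-butoxycarbonyl does the same on the core of compound 1.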